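Fluoro to chloro on the fused ring of compound 3

This account rests on a few compounds, and the source may have more. Where it says the series, first, only, none or still open, it means among the compounds named here.

Two benzothiazole amides carry the halogen on the pendant phenyl. Compound 1 `COc1ccc2nc(NC(=O)c3cn(-c4ccccc4)nc3-c3ccc(F)cc3)sc2c1` gives 12800 nM in a functional assay on PC-3 cells (Homo sapiens) for cytotoxicity, read by MTT assay, with a stated time of 72 h (on this read-out lower numbers stand for stronger inhibition and higher numbers for weaker inhibition), and compound 2 `COc1ccc2nc(NC(=O)c3cn(-c4ccccc4)nc3-c3ccc(Cl)cc3)sc2c1` gives 29300 nM in this assay. Within the data shown here, the one change between them, (chloro in place of fluoro on an aromatic carbon), produces a 2.3-fold higher number from compound 1 to compound 2 (0.36 log units; beyond the scatter).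

Compound 3 `COc1ccc(-c2nn(-c3ccccc3)cc2C(=O)Nc2nc3ccc(F)cc3s2)cc1` has the same atoms as compound 1 joined differently; the difference between the two cores is not broken down here. In this assay compound 3 gives 4930 nM, the lowest of the three numbers, with compound 1 nearest and compound 2 furthest.

Compound 4 `COc1ccc(-c2nn(-c3ccccc3)cc2C(=O)Nc2nc3ccc(Cl)cc3s2)cc1` is not yet measured. It is reached from compound 3 by chloro in place of fluoro on an aromatic carbon, the same kind of change as that from compound 1 to compound 2, but not the same: in compound 1 the place is on an aromatic carbon of a six-membered aromatic ring of carbon only, para to a large group, whereas in compound 3 it is on an aromatic carbon of a six-membered aromatic ring of carbon only, part of a fused or bridged system of two rings, meta to a fused ring and para to a fused ring.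

Among the measured compounds shown here, because the only measured instance of this kind of change gave a 2.3-fold higher number from compound 1 to compound 2 (0.36 log units; beyond the scatter), compound 4 is expected to give a higher number than compound 3, and the step is estimated as a 1.7-fold higher number from compound 3 to compound 4 (0.24 log units; within the scatter), kept somewhat tentative since the place differs. The estimate for compound 4 in this assay is 8500 nM, with a range of 3500 nM to 25000 nM.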

Compound 4, half-maximal inhibitory concentration: 6510 nM
For compound 4 the middle estimate is 1.3-fold (0.12 log units) above the measured one; the measured number falls inside the stated range.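

Working from the core of compound 3, the exchange of 6-fluoro-1,3-benzothiazol-2-yl for 6-chloro-1,3-benzothiazol-2-yl gives a 1.3-fold higher number from compound 3 to compound 4 (0.12 log units; within the scatter) in this assay, so at this place the halogen exchange cannot be told from repeat scatter. Two pairs in this assay are too few to show that the change behaves alike on further cores, and the halogen sits on a different ring in each pair, so the effect of the core and the effect of the place are not separated here. What the two pairs do support is narrower: the step that clears the scatter on one core and the step that stays within it on the other cannot be told apart as a pair: the same change on two cores in this assay, a 2.3-fold higher number (0.36 log units; beyond the scatter) from compound 1 to compound 2 and a 1.3-fold higher number (0.12 log units; within the scatter) from compound 3 to compound 4, 1.7-fold (0.24 log units) apart, within the scatter of two such steps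

The compounds shown carry only fluoro or chloro at these places, so it remains open how a bromo, a trifluoromethyl, an amine or a carboxylic acid would read on the fused ring or on the pendant phenyl. Also open, from the compounds shown here alone, is how either halogen would read with the methoxy group kept on the same ring, that is, a pair in which the halogen moves from one ring to the other while the rest of the molecule stays fixed.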